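Nitrophenyl variant on the shared core: expected growth inhibition

The source may report more compounds than this note shows. Statements on the series, on what has been measured and on what is new or still open speak of the compounds shown alone.

Measured so far:
compound 1: `O=C(/C=C/c1cccc(F)c1)NCCCCNc1ccnc2cc(Cl)ccc12` gives 15300 nM in a functional assay on MKN-28 cells (Homo sapiens) for antiproliferative activity, read by sulforhodamine B assay, with a stated time of 2 days; a lower number here means a stronger inhibitor of growth, a higher number a weaker inhibitor of growth
compound 2: `O=C(/C=C/c1ccc(F)cc1)NCCCCNc1ccnc2cc(Cl)ccc12` gives 11800 nM in this assay

Compound 2 has the lowest of the two numbers, but its nearest neighbour is compound 1 and the step of a 1.3-fold lower number from compound 1 to compound 2 (0.11 log units; within the scatter) is within the scatter, so the two compounds cannot be ordered. Among the measured compounds shown here, the only measured step, from a 3-fluorophenyl to a 4-fluorophenyl on a double-bonded chain carbon bound to a double-bonded chain carbon, thus gives no direction.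

Compound 3, `O=C(/C=C/c1ccccc1[N+](=O)[O-])NCCCCNc1ccnc2cc(Cl)ccc12`, is not yet measured. The change from compound 2 is 2-nitrophenyl in place of 4-fluorophenyl on a double-bonded chain carbon bound to a double-bonded chain carbon. For the measured compounds named here, no measured step shares this change; the one available step shifts only the position of a fluorine on the same ring and stays within the scatter. There is therefore no basis for expecting a step beyond the scatter in this assay, in either direction, and the expectation rests on the two measured compounds staying close together.

Compound 3 is therefore estimated at 12000 nM, with a range of 4000 nM to 40000 nM, which corresponds to an expected step of a 1.0-fold higher number from compound 2 to compound 3 (0.01 log units; within the scatter).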

Compound 3, concentration for 50% growth inhibition: 15100 nM
The estimate for compound 3 lay 1.3-fold (0.10 log units) below the measured number, and the stated range covers the measured number.
By their numbers in this assay, from the lowest: compounds 2, 3 and 1 (each within the scatter of the next).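

In this assay, the earlier step only moved a fluorine around the same ring, whereas here the group itself changes at the same place, on a double-bonded chain carbon bound to a double-bonded chain carbon. 2-Nitrophenyl in place of 4-fluorophenyl gives a 1.3-fold higher number from compound 2 to compound 3 (0.11 log units; within the scatter), and 2-nitrophenyl in place of 3-fluorophenyl gives a 1.0-fold lower number from compound 1 to compound 3 (0.01 log units; within the scatter), so a change of group, and not just a shift of fluorine, also leaves the three compounds indistinguishable in this assay. No measurement is available that would bear on the reason for this flat result.

The compounds shown leave open whether any group at this place can produce a step beyond the scatter, for example a ring carrying an amine or a carboxylic acid in place of the nitro group, or an unsubstituted phenyl. They also leave open whether the level shared by these three compounds is set elsewhere in the molecule, which a longer chain between the amide and the shared core could test.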